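The compounds below may be only part of what the source reports. "The series", "measured", "known", "first", "only" and "open" are said of these compounds alone.

Compound 3, with the structure `COc1cc(/C=C/C(=O)c2cccc(NC(=O)c3ccco3)c2)ccc1O`, gives 100% in a functional assay on HUVEC cells (Homo sapiens) for inhibition, tested at 10 ug/mL (on this read-out higher numbers stand for a stronger effect at the one concentration tested and lower numbers for a weaker effect), the highest of the three numbers measured. Compound 1, with the structure `COc1cc(/C=C/C(=O)c2cccc(NC(=O)c3c(Cl)cccc3Cl)c2)ccc1O`, gives 99%, and the two lie within the scatter of each other, as a number 1 percentage points higher from compound 1 to compound 3 (within the scatter) shows. Compound 2, with the structure `COc1cc(/C=C/C(=O)c2cccc(NC(=O)c3cc(Cl)cc(Cl)c3)c2)ccc1O`, gives 58%, and the step of a number 42 percentage points higher from compound 2 to compound 3 (beyond the scatter) is large, as is a number 41 percentage points lower from compound 1 to compound 2 (beyond the scatter).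

Compound 4, with the structure `COc1cc(/C=C/C(=O)c2cccc(NC(=O)C(C)C)c2)ccc1O`, differs from compound 3 in one place: isopropyl in place of furan-2-yl on a carbonyl carbon. For the measured compounds named here, no measured step replaces the furan-2-yl with a group without a ring; the measured steps exchange one ring for another, one of them within the scatter and two large. Compound 3 already stands close to the top of the scale, so the step is expected to be flat or downward. Compound 4 is therefore expected to give about 78%, between 45% and 100%, a step of a number 22 percentage points lower from compound 3 to compound 4 (beyond the scatter) from compound 3.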

Compound 4, a percentage reported as inhibition, at one concentration (the size of the read-out at that concentration, not a potency): 56%
Beside the measured number, compound 4's estimate is 22 percentage points above it, within the range that was stated.
By their numbers in this assay, from the lowest: compounds 4 and 2 (each within the scatter of the next); then compounds 1 and 3 (each within the scatter of the next).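

In this assay, for the compounds shown here, the first group without a ring at this position, on a carbonyl carbon whose other neighbour is the amide-type nitrogen, does not hold the high level: the step of a number 44 percentage points lower from compound 3 to compound 4 (beyond the scatter) is large, and so is the step of a number 43 percentage points lower from compound 1 to compound 4 (beyond the scatter) on leaving the 2,6-dichlorophenyl group. A ring alone does not decide the outcome among these four compounds, since the step of a number 2 percentage points lower from compound 2 to compound 4 (within the scatter) shows that isopropyl and the ring-bearing 3,5-dichlorophenyl group cannot be told apart here. Nothing available explains these differences.

The compounds shown leave open whether a cyclopropyl or an unsubstituted phenyl group would stay near the furan-2-yl level. They also leave open how a longer alkyl chain or an amine-bearing chain would read out at this position.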